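Shifting the Chloro Groups of Compound 3

The compounds below may be only part of what the source reports. "The series", "measured", "known", "first", "only" and "open" are said of these compounds alone.

In a functional assay on SW-620 cells (Homo sapiens) for cytotoxicity, read by MTT assay, with a stated time of 72 h (a lower number here means a stronger inhibitor, a higher number a weaker inhibitor), compound 1 `COc1cccc(/C=C2\CCC/C(=C\c3ccccc3Cl)C2=O)c1OC` gives 10300 nM while compound 2 `COc1cccc(/C=C2\CCC/C(=C\c3cccc(OC)c3OC)C2=O)c1` gives 7000 nM and compound 3 `COc1cccc(/C=C2\CCC/C(=C\c3ccc(Cl)cc3Cl)C2=O)c1OC` gives 16300 nM as its value. Compound 3 stands at the upper end of this narrow range and clearly apart only from compound 2.

Compound 4 `COc1cccc(/C=C2\CCC/C(=C\c3cc(Cl)cc(Cl)c3)C2=O)c1OC` has not yet been measured. It keeps the core of compound 3 and differs in one place 3,5-dichlorophenyl in place of 2,4-dichlorophenyl on a double-bonded chain carbon bound to a double-bonded ring carbon with 3,5-dichlorophenyl in place of 2,4-dichlorophenyl on a double-bonded chain carbon bound to a double-bonded ring carbon.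

Going by the values given here, no measured pair shows this kind of exchange, so the evidence is indirect. The nearest step is a 1.6-fold higher number from compound 1 to compound 3 (0.20 log units; within the scatter) for chloro in place of hydrogen on an aromatic carbon. The exchange of 3-methoxyphenyl for 2,4-dichlorophenyl gave a 2.3-fold higher number from compound 2 to compound 3 (0.37 log units; beyond the scatter) as a modest step, and the exchange of 2-chlorophenyl for 3-methoxyphenyl gave a 1.5-fold lower number from compound 1 to compound 2 (0.17 log units; within the scatter) in this small set. A rearrangement of the same atoms is therefore not expected to move the number far. The estimated step is a 1.5-fold lower number from compound 3 to compound 4 (0.17 log units; within the scatter) which means no expected shift beyond the scatter. In this assay compound 4 is expected at 11000 nM with an estimated range from 5000 nM to 24000 nM for its measurement.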

Compound 4, half-maximal inhibitory concentration: 5500 nM
For compound 4 the middle estimate is 2.0-fold (0.30 log units) above the measured one; low and high end bracket the measured number.
By their numbers in this assay, from the lowest: compounds 4, 2, 1 and 3 (each within the scatter of the next, the first and the last beyond it).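

In this assay, moving the two chloro groups gave a 3.0-fold lower number from compound 3 to compound 4 (0.47 log units; beyond the scatter), a step beyond the scatter with no change in the atoms of the group at this place. The earlier compounds had shown only exchanges of one group for a different one, so this is the first sign that the arrangement of the chloro groups can count here as well as their presence. Beside the other two compounds, the 3,5-dichlorophenyl group does not stand apart, with a 1.3-fold lower number from compound 2 to compound 4 (0.10 log units; within the scatter) and a 1.9-fold lower number from compound 1 to compound 4 (0.27 log units; within the scatter) both within the scatter. Going by these compounds alone, compound 1 also remains within the scatter of compound 3, so the single chloro group of 2-chlorophenyl cannot be placed clearly on either side of the gap between the two dichlorophenyl arrangements.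

The data shown offer no evidence on why the arrangement of the chloro groups matters. Going by these compounds, it remains open whether other arrangements of the two chloro groups would move the number further, and what an amine or a carboxylic acid on the phenyl group at this place would do.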